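This account rests on a few compounds, and the source may have more. Where it says the series, first, only, none or still open, it means among the compounds named here.

Of the compounds shown here, three sharing one core have been measured in a functional assay (aorta) with Oryctolagus cuniculus as the target; on this read-out higher numbers stand for weaker binding and lower numbers for tighter binding. Compound 1 (`COc1cc(C(C)=O)ccc1OCCCN1CCC(C(c2ccc(F)cc2)c2ccc(F)cc2)CC1`) gives 1.59 nM, compound 2 (`COc1cc(OCCCN2CCC(C(c3ccc(F)cc3)c3ccc(F)cc3)CC2)ccc1C(C)=O`) gives 3.16 nM, and compound 3 (`Nc1ccc(OCCCN2CCC(C(c3ccc(F)cc3)c3ccc(F)cc3)CC2)cc1`) gives 31.6 nM, the highest number of the three. Compound 4 (`Fc1ccc(C(c2ccc(F)cc2)C2CCN(CCCCc3ccccc3)CC2)cc1`) departs from compound 3 by one change: benzyl in place of 4-aminophenoxy on a saturated chain carbon, three bonds along the chain from an amine nitrogen in a ring. Two measured steps, a 20-fold higher number from compound 1 to compound 3 (1.30 log units; beyond the scatter) and a 10-fold higher number from compound 2 to compound 3 (1.00 log units; beyond the scatter), lie beyond the scatter, so among these compounds the group on the oxygen can clearly move the number, while a 2.0-fold higher number from compound 1 to compound 2 (0.30 log units; within the scatter) stays within the scatter. None of these steps puts benzyl in place of 4-aminophenoxy, so they give no direction, and no step beyond the scatter is expected. The estimated step is a 1.3-fold lower number from compound 3 to compound 4 (0.10 log units; within the scatter). For compound 4 the expected value is 25 nM, with an estimated range from 5 nM to 120 nM.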

Compound 4, dissociation constant: 2.51 nM
Beside the measured number, compound 4's estimate is 10-fold (1.00 log units) above it; the measured number lies below the stated range.
By their numbers in this assay, from the lowest: compounds 1, 4 and 2 (each within the scatter of the next); then compound 3.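

In this assay benzyl in place of 4-aminophenoxy gives a 13-fold lower number from compound 3 to compound 4 (1.10 log units; beyond the scatter), so this position tolerates a group with no oxygen and no hydrogen-bond donors or acceptors. The other two steps, a 1.3-fold lower number from compound 2 to compound 4 (0.10 log units; within the scatter) and a 1.6-fold higher number from compound 1 to compound 4 (0.20 log units; within the scatter), stay within the scatter, which puts benzyl level with both acetyl-methoxyphenoxy groups. Nothing measured here gives a reason for these results.

Still open, from the compounds shown here alone, is how plain phenoxy, carrying no amine or acetyl, would read at this position. Also open, going by these compounds, is whether a longer chain ending in phenyl would hold the number of compound 4.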